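The source may hold more compounds than are shown below. What is called first, only, known or untested is meant among the compounds shown, and "the series" means these compounds.

Of the compounds shown here, three sharing one core have been measured in an assay on isolated protein with dual specificity calcium/calmodulin-dependent 3',5'-cyclic nucleotide phosphodiesterase 1B (Bos taurus) as the target, tested at 100 uM; a lower number here means less inhibition, a higher number more inhibition at the concentration tested (going by the name of the read-out). Compound 1 `Nc1nc2c(c(=O)n(CC3CC3)c(=O)n2CC2CC2)n1S(=O)(=O)c1ccccc1` gives 13%, compound 2 `COc1ccc(S(=O)(=O)n2c(N)nc3c2c(=O)n(CC2CC2)c(=O)n3CC2CC2)cc1` gives 25%, and compound 3 `COc1ccc(S(=O)(=O)Nc2nc3c(c(=O)n(CC4CC4)c(=O)n3CC3CC3)n2C)cc1` gives 32%. The number for compound 3 is the largest of the three, though compound 2 lies within the usual scatter of it and only compound 1 sits clearly lower. Compound 4 `COc1ccc(S(=O)(=O)Nc2nc3c(c(=O)n(CC4CC4)c(=O)n3CC3CC3)n2Cc2cc(OC)c(OC)c(OC)c2)cc1` differs from compound 3 by 3,4,5-trimethoxyphenyl in place of hydrogen on a saturated chain carbon bound to an aromatic nitrogen. Going by the values given here, the single measured step, a number 12 percentage points higher from compound 1 to compound 2 (beyond the scatter), concerns a methoxy on an aromatic carbon and does not bear on this change; no measured step does. With nothing to guide the direction, no step beyond the scatter is expected in this assay, and compound 4 is estimated at 35% (range 15% to 60%), a step of a number 3 percentage points higher from compound 3 to compound 4 (within the scatter).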

Compound 4, a percentage reported as inhibition, at one concentration (the size of the read-out at that concentration, not a potency): 52%
Compound 4: middle estimate off by 17 percentage points, on the low side; the range from low to high includes it.
By their numbers in this assay, from the lowest: compound 1; then compounds 2 and 3 (each within the scatter of the next); then compound 4.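

In this assay, 3,4,5-trimethoxyphenyl in place of hydrogen on a saturated chain carbon bound to an aromatic nitrogen gives a number 20 percentage points higher from compound 3 to compound 4 (beyond the scatter). Going by these compounds alone, this is the first measured change at this position, and it shows that a group of 12 heavy atoms placed there is compatible with greater inhibition at the concentration tested. Nothing available explains the rise. From the compounds shown here alone, whether the aromatic ring or its methoxy groups carry the gain remains open, as does the outcome with a plain phenyl, an amine or a carboxylic acid on the same carbon.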